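Removing the Acetyl from Compound 2 on Cancer Cells

A few compounds are considered here, and "the series" means these few. Any claim that something is new, unique, unknown or untested is made for them only; others in the source may bear on it.

Measured so far:
Compound 1, `COc1c(NS(=O)(=O)C2CC2)cc(-c2ccc3nc(NC(C)=O)nn3c2)cc1C(N)=O`, gives 36300 nM in a functional assay on HCT-116 cells (Homo sapiens) for antiproliferative activity, read by MTT assay, with a stated time of 72 h; on this read-out lower numbers stand for stronger inhibition and higher numbers for weaker inhibition.
Compound 2, `COc1c(NS(=O)(=O)c2ccc(F)cc2)cc(-c2ccn3nc(NC(C)=O)nc3c2)cc1C(N)=O`, gives 32600 nM in this assay.
Compound 3, `COc1c(NS(=O)(=O)c2ccc(F)cc2)cc(-c2ccc3nc(NC(=O)C4CC4)sc3c2)cc1C(N)=O`, gives 2010 nM in this assay.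

Among these three numbers compound 2 has the second highest. Its nearest neighbour is compound 1, whose value lies within the usual scatter of compound 2, so the two cannot be told apart. Compound 3 stands well apart, with a number beyond the scatter and far lower than that of compound 2; the two differ in more than one place, so nothing about any single group can be read from that gap.

Compound 4, `COc1c(NS(=O)(=O)c2ccc(F)cc2)cc(-c2ccn3nc(N)nc3c2)cc1C(N)=O`, is the compound still to be measured. It differs from compound 2 in one place: hydrogen in place of acetyl on a nitrogen on an aromatic ring. Going by the values given here, no pair of measured compounds shows this change alone, so there is no measured step to lean on. With the value of compound 2 already weak, the expectation is that removing the acetyl leaves compound 4 at a similar or somewhat higher number, a step of a 1.5-fold higher number from compound 2 to compound 4 (0.19 log units; within the scatter) that may stay within the scatter. The estimate for compound 4 is 50000 nM, expected to fall between 15000 nM and 150000 nM.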

Compound 4, half-maximal inhibitory concentration: > 50000 nM
Compound 4: no number, only a limit (the forecaster's own chance of this, stated with the estimate: 30%); the middle value sits exactly at the limit.
By their numbers in this assay, from the lowest: compound 3; then compounds 2 and 1 (each within the scatter of the next). At a limit, above all of these: compound 4.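

For compound 4 the reading in this assay is > 50000 nM, which is a limit of the assay and not a number. Replacing the acetyl with hydrogen on this nitrogen, the change from acetamido to amino, gives an at least 1.5-fold higher number from compound 2 to compound 4 (0.18 log units; that floor lies within the scatter), the first step among these compounds that isolates a single change at this position. That floor lies within the scatter, so the result shows only that removing the acetyl brought no measurable gain in inhibition on these cells, while the true size of the step remains unknown and could be small or large; the reading for this compound stops at a limit: the limit of > 50000 nM in this assay, at which 1 of the 4 values shown sits.

The compounds shown leave open how much weaker compound 4 really is than compound 2, a question that a reading stopping at a limit cannot settle. They also leave open whether a different group on this nitrogen, such as a methyl group or a longer acyl chain like butanoyl, would give a number clearly lower than that of compound 2.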